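Swapping a thiophene for a chlorophenyl on a hydrazone

The source may report more compounds than this note shows. Statements on the series, on what has been measured and on what is new or still open speak of the compounds shown alone.

Measured compounds:
compound 1 `Cn1c(=O)c(=O)n(C2CCCC2)c2nc(N/N=C/c3cc(C(F)(F)F)c(O)c(C(F)(F)F)c3)ncc21` — 27100 nM
compound 2 `Cn1c(=O)c(=O)n(C2CCCC2)c2nc(N/N=C/c3cccs3)ncc21` — 52600 nM
compound 3 `Cn1c(=O)c(=O)n(C2CCCC2)c2nc(N/N=C/c3cc(C(F)(F)F)cc(C(F)(F)F)c3)ncc21` — 4360 nM

In a functional assay on HCT-116 cells (Homo sapiens) for antiproliferative activity, read by MTT assay (on this read-out higher numbers stand for weaker inhibition and lower numbers for stronger inhibition), compound 2 gives the highest of the three numbers; compound 1 sits within the scatter of it, while compound 3 lies well below it. For the measured compounds named here, the only measured step, a 6.2-fold lower number from compound 1 to compound 3 (0.79 log units; beyond the scatter), concerns a hydroxy group and says nothing directly about exchanging the aromatic ring itself. Compound 4 `Cn1c(=O)c(=O)n(C2CCCC2)c2nc(N/N=C/c3ccccc3Cl)ncc21` differs from compound 2 by 2-chlorophenyl in place of thiophen-2-yl on a carbon with a double bond to nitrogen. With no step bearing on this ring exchange, the expectation rests on the spread of the three aryl and heteroaryl hydrazones shown. For compound 4 the estimate is 15000 nM, within 4000 nM to 50000 nM, which would mean an expected 3.5-fold lower number from compound 2 to compound 4 (0.54 log units; beyond the scatter).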

Compound 4, half-maximal inhibitory concentration: 14000 nM
Beside the measured number, compound 4's estimate is 1.1-fold (0.03 log units) above it; measured number inside the range.
By their numbers in this assay, from the lowest: compound 3; then compounds 4, 1 and 2 (each within the scatter of the next, the first and the last beyond it).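

Putting 2-chlorophenyl in place of thiophen-2-yl gives a 3.8-fold lower number from compound 2 to compound 4 (0.57 log units; beyond the scatter) in this assay, the first step shown in which the aromatic ring itself changes, not just a group on it. The read-out therefore responds to this exchange on the carbon with a double bond to nitrogen. Nothing measured explains the step.

This one step swaps the ring and adds chlorine together, so their contributions cannot be separated. Also open, as far as these compounds go, is how an unsubstituted phenyl ring, or a phenyl ring carrying an amine or a carboxylic acid in place of chlorine, would behave in this assay.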